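The source may hold more compounds than are shown below. What is called first, only, known or untested is meant among the compounds shown, and "the series" means these compounds.

Compound 1 `COc1ccc(C2=NN(C(=O)c3ccc(Cl)nc3)C(c3ccc(OC)cc3)C2)cc1` gives 6450 nM in a functional assay on WM 266-4 cells (Homo sapiens) for antiproliferative activity, read by MTT assay, with a stated time of 24 h; a lower number here means a stronger inhibitor of growth, a higher number a weaker inhibitor of growth. Compound 2 `COc1ccc(C2=NN(C(=O)c3ccc(Cl)nc3)C(c3ccc(Cl)cc3)C2)cc1` differs from compound 1 by chloro in place of methoxy on an aromatic carbon; in this assay compound 2 gives 1450 nM, so that a 4.4-fold lower number from compound 1 to compound 2 (0.65 log units; beyond the scatter). Compound 3 `COc1ccc(C2=NN(C(=O)c3cncc(Br)c3)C(c3ccc(OCc4ccccc4)cc3)C2)cc1` gives 6240 nM in this assay; the difference between its core and the core of compound 1 is not broken down here, and the two values lie within the scatter of each other. Compound 4 `O=C(c1cncc(Br)c1)N1N=C(c2ccc(Cl)cc2)CC1c1ccc(OCc2ccccc2)cc1` is not yet measured; it differs from compound 3 by chloro in place of methoxy on an aromatic carbon, the same change that separates compound 1 from compound 2, at the same kind of place. Because a 4.4-fold lower number from compound 1 to compound 2 (0.65 log units; beyond the scatter) was modest but beyond the scatter, a step of similar size is expected here, a 3.5-fold lower number from compound 3 to compound 4 (0.54 log units; beyond the scatter), resting on that single precedent. For compound 4 the estimate in this assay is 1800 nM, expected between 700 nM and 4500 nM.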

Compound 4, concentration for 50% growth inhibition: 8130 nM
Compound 4: middle estimate off by 4.5-fold (0.65 log units), on the low side, and the stated range ends below it.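

On the core of compound 3, the change from 4-methoxyphenyl to 4-chlorophenyl gives a 1.3-fold higher number from compound 3 to compound 4 (0.11 log units; within the scatter) in this assay, so the lower number seen on the core of compound 1 does not reappear. The change therefore does not carry over between these two cores as a step of constant size: the same change on two cores in this assay, a 4.4-fold lower number (0.65 log units; beyond the scatter) from compound 1 to compound 2 and a 1.3-fold higher number (0.11 log units; within the scatter) from compound 3 to compound 4, 5.8-fold (0.76 log units) apart, beyond the scatter of two such steps

This rests on only two pairs, and the two cores differ in more than one place, so neither the part of the core that governs the step nor the reason for the gap is shown. Still open, going by these compounds, is which core difference matters, and whether fluoro, methyl or an amine in place of chloro would follow either step.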